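Pyrazin-2-yl Swapped for 6-Chloropyridin-2-yl on the Core

The source may hold more compounds than are shown below. What is called first, only, known or untested is meant among the compounds shown, and "the series" means these compounds.

Compound 1 `N#Cc1ccc(-c2nc(N)c3cc(Cc4ccccc4)sc3n2)o1`: 3160 nM
Compound 2 `Nc1nc(-c2ccc(C(F)F)o2)nc2sc(Cc3ccccc3)cc12`: 3000 nM
Compound 3 `Nc1nc(-c2cnccn2)nc2sc(Cc3ccccc3)cc12`: 91 nM

In a functional assay on CHO-K1 cells for antagonist activity at adenosine receptor A1 (Homo sapiens), read by a beta-galactosidase reporter and cAMP accumulation, with stated times of 15 min and 6 h (on this read-out higher numbers stand for weaker inhibition and lower numbers for stronger inhibition), compound 3 gives 91 nM and stands lowest of the three measured numbers, reached through a 35-fold lower number from compound 1 to compound 3 (1.54 log units; beyond the scatter) and a 33-fold lower number from compound 2 to compound 3 (1.52 log units; beyond the scatter), while a 1.1-fold lower number from compound 1 to compound 2 (0.02 log units; within the scatter) stayed flat. Compound 4 `Nc1nc(-c2cccc(Cl)n2)nc2sc(Cc3ccccc3)cc12` differs from compound 3 in one place: 6-chloropyridin-2-yl in place of pyrazin-2-yl on an aromatic carbon. Within the data shown here, both large measured steps replaced a five-membered ring by pyrazin-2-yl; no measured step exchanges one six-membered ring for another, so only an indirect reading is possible. As far as these compounds go, compound 4 keeps a six-membered aromatic ring but with one hetero atom instead of two, and the 6-chloropyridin-2-yl group is untested here. Compound 4 is therefore expected to stay nearer to compound 3 than to compound 1, with a step of a 2.4-fold higher number from compound 3 to compound 4 (0.38 log units; beyond the scatter) toward a somewhat higher number, estimated at 220 nM within 60 nM to 800 nM.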

Compound 4, inhibition constant: > 1000 nM
Compound 4: no number, only a limit; the forecaster's own chance of this, stated with the estimate: 5%; at least 4.5-fold (0.65 log units) between middle value and limit.
By their numbers in this assay, from the lowest: compound 3; then compounds 2 and 1 (each within the scatter of the next).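

In this assay compound 4 is recorded only as a limit of the assay: the limit of > 1000 nM in this assay, at which 1 of the 4 values shown sits. Even so, exchanging one six-membered aromatic ring for another at this position gives an at least 10-fold higher number from compound 3 to compound 4 (1.04 log units; beyond the scatter), so a six-membered ring alone does not keep the number low, which the earlier large steps, both from five-membered rings, could not show. The steps between compound 1 or compound 2 and compound 4 cannot be read.

Whether the chlorine or the missing second ring nitrogen accounts for the step stays open. A plain pyridin-2-yl group at this position would separate the two.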